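Swapping the amide side chain on a thiazole hydroxamate

The source may report more compounds than this note shows. Statements on the series, on what has been measured and on what is new or still open speak of the compounds shown alone.

Compound 3 `O=C(CCCCCCN(Cc1ccc(F)cc1)c1ncc(C(=O)NCCCn2ccnc2)s1)NO` gives 19 nM in an assay on isolated protein for inhibition of Nicotinamide phosphoribosyltransferase (Homo sapiens), read by fluorescence, with stated times of 5 min and 15 min; a higher number here means a weaker inhibitor, a lower number a stronger inhibitor. That is the second highest of the three numbers: compound 2 `O=C(CCCCCCCN(Cc1ccc(F)cc1)c1ncc(C(=O)NCCCn2ccnc2)s1)NO` gives 18 nM, a step of a 1.1-fold higher number from compound 2 to compound 3 (0.02 log units; within the scatter), while compound 1 `CC(C)CCN(CCCCCCC(=O)NO)c1ncc(C(=O)NCc2cccnc2)s1` gives 220 nM, well beyond the scatter from compound 3. Compound 4 `O=C(CCCCCCN(Cc1ccc(F)cc1)c1ncc(C(=O)NCc2cccnc2)s1)NO` carries pyridin-3-yl in place of 2-(1H-imidazol-1-yl)ethyl on a saturated chain carbon bound to an amide-type nitrogen. Among the compounds with values here, no measured step isolates this change; the only measured step concerns chain length. Compound 1 shares the pyridinylmethyl amide of compound 4 but also differs in the group on the ring nitrogen, so its weaker number cannot be assigned to one change. A modest weakening is expected, a 2.4-fold higher number from compound 3 to compound 4 (0.37 log units; beyond the scatter), with wide uncertainty. Compound 4 is therefore estimated at 45 nM, within 12 nM to 170 nM.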

Compound 4, half-maximal inhibitory concentration: 470 nM
Compound 4: the middle estimate sits 10-fold (1.02 log units) below what was measured; measured number above the stated range.
By their numbers in this assay, from the lowest: compounds 2 and 3 (each within the scatter of the next); then compound 1; then compound 4.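

Within the data shown here, the amide side chain carries far more weight than the earlier compounds could show: in this assay, (pyridin-3-yl)methyl in place of 3-(1H-imidazol-1-yl)propyl gives a 25-fold higher number from compound 3 to compound 4 (1.39 log units; beyond the scatter). With the (pyridin-3-yl)methyl amide held fixed, 4-fluorophenyl in place of isobutyl, on a saturated chain carbon bound to a nitrogen on an aromatic ring, gives a much smaller weakening, a 2.1-fold higher number from compound 1 to compound 4 (0.33 log units; beyond the scatter). No measurement here accounts for the large loss. The compounds shown leave open whether that loss follows the ring or the chain carrying it. A 3-(pyridin-3-yl)propyl group on the amide would separate the two.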